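From a Methoxy to a Trifluoromethyl Group: Estimating Compound 4

This account rests on a few compounds, and the source may have more. Where it says the series, first, only, none or still open, it means among the compounds named here.

Compound 1 `CCOC(=O)c1c(-c2cccc(C(F)(F)F)c2)csc1N`: 30%
Compound 2 `Cc1cccc(-c2csc(N)c2C(=O)OCc2ccccc2)c1`: 68%
Compound 3 `COc1cccc(-c2csc(N)c2C(=O)OCc2ccccc2)c1`: 57%

Of the compounds shown here, three have been measured in an assay on isolated protein for inhibition of protein kinase C zeta type (Homo sapiens), with stated times of 1 h and 2.5 min, tested at 30 uM; a lower number here means less inhibition, a higher number more inhibition at the concentration tested (going by the name of the read-out). Compound 3 gives 57% and stands second highest of the three; its nearest neighbour is compound 2 with 68%, while compound 1 lies furthest away with 30%. For the measured compounds named here, the one measured step that changes a single place is a number 11 percentage points lower from compound 2 to compound 3 (beyond the scatter), methoxy in place of methyl on an aromatic carbon, a modest drop beyond the scatter.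

Compound 4 `Nc1scc(-c2cccc(C(F)(F)F)c2)c1C(=O)OCc1ccccc1` differs from compound 3 as follows: trifluoromethyl in place of methoxy on an aromatic carbon. No measured step exchanges a methoxy for a trifluoromethyl, so the only direct guide is that compound 1, which also carries a trifluoromethyl group but a different ester, gives 30%, the lowest number shown. Compound 1 and compound 3 differ in two places, so its value can be weighed only loosely. The step from methyl to methoxy was modest; a further change at the same carbon is therefore expected to move this assay by a small to moderate amount, most likely downward. Compound 4 is expected to give 48%, within 28% to 68%, which corresponds to an estimated step of a number 9 percentage points lower from compound 3 to compound 4 (within the scatter).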

Compound 4, a percentage reported as inhibition, at one concentration (the size of the read-out at that concentration, not a potency): 29%
The estimate for compound 4 lay 19 percentage points above the measured number, and the stated range covers the measured number.
By their numbers in this assay, from the lowest: compounds 4 and 1 (each within the scatter of the next); then compound 3; then compound 2.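

In this assay, the aromatic carbon meta to a large group proves sensitive to the choice of group: trifluoromethyl gives a number 28 percentage points lower from compound 3 to compound 4 (beyond the scatter) and a number 39 percentage points lower from compound 2 to compound 4 (beyond the scatter), whereas methoxy alone had given a number 11 percentage points lower from compound 2 to compound 3 (beyond the scatter). With trifluoromethyl in place, the ester matters little in this pair, with a number 1 percentage points lower from compound 1 to compound 4 (within the scatter), so the low number of the earlier trifluoromethyl compound now tracks that group rather than its ester. No measurement shown explains why trifluoromethyl lowers the number at this carbon.

From the compounds shown here alone, whether the ester change would prove equally small with methyl or methoxy on this carbon remains open. So does where a chlorine, a nitrile or an amine on the same carbon would fall relative to these three groups.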